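Aminophenyl Replaces a Sulfonamide on a Shared Core

The source may report more compounds than this note shows. Statements on the series, on what has been measured and on what is new or still open speak of the compounds shown alone.

Compound 1 has the structure `C[C@@H](CO)NS(=O)(=O)c1cccc(-c2ccc3nccc(-c4ccncc4)c3n2)c1`. In a physicochemical assay for solubility, read by HPLC, using the shake flask method, measured as kinetic solubility, with a stated time of 20 h, at pH 6.5, tested at 200 uM (on this read-out lower numbers stand for lower solubility and higher numbers for higher solubility), compound 1 gives 50000 nM, the highest of the two numbers shown. Compound 2, with the structure `O=S(=O)(c1cccc(Nc2ccc3nccc(-c4ccncc4)c3n2)c1)N1CCCCC1`, gives 15000 nM in this assay, a value that sits beyond the scatter from compound 1. Compound 3, with the structure `Cc1ccc(-c2ccnc3ccc(-c4cccc(S(N)(=O)=O)c4)nc23)cn1`, is reported only as a limit of this assay, < 5000 nM, with no number behind it; this is the limit of < 5000 nM in this assay, at which 1 of the 3 values shown sits.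

No pair among these three differs in one place only, so the measured values alone do not show what any single change does to solubility.

The compound that has not yet been tested is compound 4, with the structure `Nc1cccc(-c2ccc3nccc(-c4ccncc4)c3n2)c1`. Compared with compound 1 it carries amino in place of (1-(hydroxymethyl)ethyl)sulfamoyl on an aromatic carbon. Within the data shown here, for a change of this kind there is no measured step here to lean on. The expectation for compound 4 is a step from compound 1 of a 2.5-fold lower number from compound 1 to compound 4 (0.40 log units; beyond the scatter), downward but by an uncertain amount, with a real chance that only a limit comes back. The estimated solubility of compound 4 is 20000 nM, between 5000 nM and 80000 nM.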

Compound 4, solubility: < 5000 nM
Compound 4 was reported as a limit; the forecaster's own chance of this, stated with the estimate: 25%; middle value at least 4.0-fold (0.60 log units) from the limit.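

In this assay compound 4 returns < 5000 nM, which is a limit of the assay and not a number. Among these compounds, compound 1 and compound 4 form the first pair here that differs in one place only, so one change on an aromatic carbon can now be followed by itself: with amino in place of (1-(hydroxymethyl)ethyl)sulfamoyl, the step is an at least 10-fold lower number from compound 1 to compound 4 (1.00 log units; beyond the scatter). The full size of this step cannot be read from the pair, and the result for compound 4 now stands with that of one other compound shown: the limit of < 5000 nM in this assay, at which 2 of the 4 values shown sit.

This single step removes the whole (1-(hydroxymethyl)ethyl)sulfamoyl group at once, so it leaves open how much of the drop belongs to the sulfonyl part, how much to the hydroxyl-bearing chain, and how much to the amino group that enters. Compounds on the shared core with a carboxylic acid, a dimethylamino group or a simple 2-hydroxyethyl chain on this same aromatic carbon would be needed to separate these parts, and a reading above the limit for any of them would give a step of known size.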